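Extending the Dimethylamino Chain Once More

The source may hold more compounds than are shown below. What is called first, only, known or untested is meant among the compounds shown, and "the series" means these compounds.

In a functional assay on HeLa cells (Homo sapiens) for antiproliferative activity, read by MTT assay, with a stated time of 48 h (a lower number here means a stronger inhibitor, a higher number a weaker inhibitor), compound 1 `CN(C)CCn1c(N)c(-c2nc3ccccc3s2)c2nc(C#N)c(C#N)nc21` reaches only a limit, > 50000 nM. For the measured compounds named here, compound 2 `CN(C)CCCn1c(N)c(-c2nc3ccccc3s2)c2nc(C#N)c(C#N)nc21` gives 720 nM, the only actual number so far. Compound 3 `CN(C)CCCCn1c(N)c(-c2nc3ccccc3s2)c2nc(C#N)c(C#N)nc21` carries 4-(dimethylamino)butyl where compound 2 has 3-(dimethylamino)propyl: (dimethylamino)methyl in place of dimethylamino on a saturated chain carbon, three bonds along the chain from an aromatic nitrogen. On these data alone, the same kind of change one bond nearer the aromatic nitrogen gave an at least 69-fold lower number from compound 1 to compound 2 (1.84 log units; beyond the scatter), a large step, but it rests on (the limit of > 50000 nM in this assay, at which 1 of the 2 values shown sits), and its true size remains unknown. That single step is a weak guide, so no clear shift is expected in this assay. The expected step is a 1.2-fold lower number from compound 2 to compound 3 (0.08 log units; within the scatter), probably within the scatter. For compound 3 the estimated value is 600 nM, with an expected range of 150 nM to 3500 nM.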

Compound 3, half-maximal inhibitory concentration: 18700 nM
Estimate against measurement, compound 3: 31-fold (1.49 log units) below; measured number outside the range, above it.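

In this assay, lengthening the chain stops helping at this position: adding one more carbon to 3-(dimethylamino)propyl reverses the earlier gain, with a 26-fold higher number from compound 2 to compound 3 (1.41 log units; beyond the scatter). Compound 2 therefore stands out as the most potent of the three, so the response to chain length is a sharp optimum rather than a steady trend. The 4-(dimethylamino)butyl chain still compares favourably with the shortest chain, with an at least 2.6-fold lower number from compound 1 to compound 3 (0.42 log units; beyond the scatter), though this size is only a bound: the limit of > 50000 nM in this assay, at which 1 of the 3 values shown sits.

On these data alone, whether a longer chain would lose still more remains open. So does whether a morpholine or a primary amine in place of dimethylamino would hold the potency of compound 2.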